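A few compounds are considered here, and "the series" means these few. Any claim that something is new, unique, unknown or untested is made for them only; others in the source may bear on it.

Measured so far:
- compound 1, `CC(C)Oc1cccc(-c2ccc(C(=O)N(Cc3cccc(OCCCCCC(=O)O)c3)C(C)C)cc2)c1`: in an ADME assay on HepG2 cells (Homo sapiens) for cytotoxicity, read by CellTiter-Glo and resazurin assay, with a stated time of 72 h (a lower number here means that less compound is needed, a higher number that more compound is needed for the effect), compound 1 gives > 26000 nM, a limit of the assay
- compound 2, `CCOC(=O)CCCCCOc1cccc(CN(C(=O)c2ccc(-c3ccc4ccccc4c3)cc2)C(C)C)c1`: in this assay compound 2 gives > 26000 nM, likewise a limit of the assay

Going by the values given here, compound 2 therefore stands only at a limit, not at a number, and the one further value shown is a limit as well. Both sit at the limit of > 26000 nM in this assay, at which 2 of the 2 values shown sit. Compound 3, `CCOC(=O)CCCCCOc1cccc(CN(C(=O)c2ccc(-c3cccc(OCC(C)C)c3)cc2)C(C)C)c1`, is not yet measured in this assay. It differs from compound 2 by 3-(isobutoxy)phenyl in place of naphthalen-2-yl on an aromatic carbon. Among the compounds with values here, no step between measured compounds is on record, so no size can be read from the data. Compound 1, whose structure is shown, also sits at the limit. The step that the limit leaves unreadable from compound 2 to compound 3 is expected to be none beyond the scatter, with compound 3 expected to remain at the limit. The estimate for compound 3 is 35000 nM, with a range from 15000 nM to 120000 nM.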

Compound 3, half-maximal effective concentration: > 26000 nM
Compound 3 gave a limit, no number (the forecaster's own chance of this, stated with the estimate: 85%); the middle value is on the limit's open side.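

In this assay, going by these compounds alone, compound 2 and compound 3 both stand only at a limit, so no step between them can be read. The compounds shown leave open how naphthalen-2-yl and 3-(isobutoxy)phenyl compare, and at what concentration, if any, these compounds would give an actual number.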